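The source may hold more compounds than are shown below. What is called first, only, known or untested is meant among the compounds shown, and "the series" means these compounds.

Among the measured compounds shown here, compound 1 `O=C(N/N=C/c1coc2ccc(O)cc2c1=O)c1cc2ccccc2[nH]1` is the only compound with an actual number in an assay for inhibition of Alpha amylase (Homo sapiens); a higher number here means a weaker inhibitor, a lower number a stronger inhibitor: compound 1 gives 151000 nM. Compound 2 `Cc1ccc(S(=O)(=O)Oc2ccc(/C=N/NC(=O)c3nc4ccccc4[nH]3)cc2)cc1` reaches only a limit of the assay, > 200000 nM, with no number beneath it. Compound 3 `Cc1ccc(S(=O)(=O)Oc2ccc(/C=N/NC(=O)c3ccc(O)cc3)cc2)cc1` likewise stops at a limit, > 200000 nM. For the measured compounds named here, the one step between measured neighbours is a step that the two limits leave unreadable from compound 2 to compound 3, so it tells nothing about size. Going by the values given here, the weight of the data is the limit of > 200000 nM in this assay, at which 2 of the 3 values shown sit, which leaves no step to read. Compound 4 `O=C(N/N=C/c1coc2ccccc2c1=O)c1cc2ccccc2[nH]1` differs from compound 1 by hydrogen in place of hydroxy on an aromatic carbon. Among the compounds with values here, no measured step touches a hydroxy group, so nothing here says how large this change should be, and the starting point already lies close to the limit. The expected outcome is a step of a 1.5-fold higher number from compound 1 to compound 4 (0.16 log units; within the scatter), no larger than the scatter. Compound 4 is therefore estimated at 220000 nM, between 80000 nM and 600000 nM, with a real chance that it, too, reports only a limit.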

Compound 4, half-maximal inhibitory concentration: 128000 nM
Beside the measured number, compound 4's estimate is 1.7-fold (0.24 log units) above it, and the stated range covers the measured number.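

In this assay, putting hydrogen in place of hydroxy on this aromatic carbon gives a 1.2-fold lower number from compound 1 to compound 4 (0.07 log units; within the scatter), so the hydroxy group makes no difference here that can be told from the scatter of the assay. Among the compounds shown here, this is the first step in the set that can be read, as the step from compound 2 to compound 3 cannot be read, and it shows that the core of compound 1 still gives a real number without this group. Even so, the readable range remains narrow, and much of the set gives no number at all: the limit of > 200000 nM in this assay, at which 2 of the 4 values shown sit.

The compounds shown leave open whether a methoxy group, an amine or a carboxylic acid on this same carbon would move the number beyond the scatter. They also leave open whether swapping hydroxy for hydrogen would behave the same way on a different core.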